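An ethoxycarbonyl swap where only limits are known

The source may report more compounds than this note shows. Statements on the series, on what has been measured and on what is new or still open speak of the compounds shown alone.

Compound 1 `CCOCCOC(=O)C(=O)Nc1nc(-c2cc(OCc3ccccc3)no2)cs1` and compound 2 `CCOCCOC(=O)C(=O)Nc1nc(-c2cc(-c3c(F)cccc3Cl)no2)cs1` share their core. In a functional assay on the whole organism with Rattus norvegicus as the target (on this read-out lower numbers stand for an effect already at smaller amounts and higher numbers for an effect only at larger amounts of compound), compound 1 gives > 100 mg/kg, which is a limit. In this assay compound 2 gives > 30 mg/kg, also a limit, so it has no exact number. Compound 3 `CCOCCOC(=O)C(=O)Nc1nc(-c2cc(C(=O)OCC)no2)cs1` carries ethoxycarbonyl in place of 2-chloro-6-fluorophenyl on an aromatic carbon. Among the measured compounds shown here, the only measured step, a step that the two limits leave unreadable from compound 1 to compound 2, changes that same carbon, yet it shows neither size nor direction for this assay. The expected step that the limit leaves unreadable from compound 2 to compound 3 is therefore only a loose estimate. The estimated value for compound 3 is 40 mg/kg, within a range from 10 mg/kg to 150 mg/kg.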

Compound 3, dose for half-maximal effect: 1.9 mg/kg
For compound 3 the middle estimate is 21-fold (1.32 log units) above the measured one, and the stated range ends above it.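

The aromatic carbon next to the ring nitrogen clearly responds to the group it carries: in this assay, ethoxycarbonyl in place of 2-chloro-6-fluorophenyl gives an at least 15-fold lower number from compound 2 to compound 3 (1.19 log units; beyond the scatter), and ethoxycarbonyl in place of benzyloxy gives an at least 52-fold lower number from compound 1 to compound 3 (1.72 log units; beyond the scatter). Compound 1 has only a limit: the limit of > 100 mg/kg in this assay, at which 1 of the 3 values shown sits. Compound 2 also has only a limit, so both steps are minimum sizes: the limit of > 30 mg/kg in this assay, at which 1 of the 3 values shown sits. The step between the two limits still cannot be read. As far as these compounds go, it remains open what a carboxylic acid, a primary amide or a longer ester chain would give at this carbon.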